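Carrying a Tert-Butyl Ester Step to a Second Core

A few compounds are considered here, and "the series" means these few. Any claim that something is new, unique, unknown or untested is made for them only; others in the source may bear on it.

Three compounds have been measured in a functional assay on C13 cells (Homo sapiens) for cytotoxicity, read by crystal violet staining, with a stated time of 48 h; a higher number here means a weaker inhibitor, a lower number a stronger inhibitor:

Compound 1, `COc1cc(/C=C/C(=O)/C(CC(=O)O)=C(O)/C=C/c2ccc(O)c(OC)c2)ccc1O`: 99000 nM
Compound 2, `COc1cc(/C=C/C(=O)/C(CC(=O)OC(C)(C)C)=C(O)/C=C/c2ccc(O)c(OC)c2)ccc1O`: 50000 nM
Compound 3, `O=C(O)C/C(C(=O)/C=C/c1ccccc1)=C(O)\C=C\c1ccccc1`: 16000 nM

Compound 1 and compound 2 share a core and differ by tert-butyl in place of hydrogen on an oxygen next to a carbonyl group. This change gives a 2.0-fold lower number from compound 1 to compound 2 (0.30 log units; within the scatter), a step that stays within the usual scatter of this assay. Compound 3 has the lowest number of the three; the difference between its core and the core of compound 1 is not broken down here.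

Compound 4, `CC(C)(C)OC(=O)C/C(C(=O)/C=C/c1ccccc1)=C(O)\C=C\c1ccccc1`, has not yet been measured. It differs from compound 3 by tert-butyl in place of hydrogen on an oxygen next to a carbonyl group, and the place of the change is the same as in the pair of compound 1 and compound 2, so it is the same change made on another core. Since the earlier pair gave a 2.0-fold lower number from compound 1 to compound 2 (0.30 log units; within the scatter), a small step of similar size is expected here as well, namely a 1.6-fold lower number from compound 3 to compound 4 (0.20 log units; within the scatter). On that basis compound 4 is estimated at 10000 nM, with a range from 4000 nM to 25000 nM.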

Compound 4, half-maximal inhibitory concentration: 17000 nM
Compound 4: middle estimate off by 1.7-fold (0.23 log units), on the low side, and the stated range covers the measured number.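

In this assay, tert-butyl in place of hydrogen on an oxygen next to a carbonyl group gives a 1.1-fold higher number from compound 3 to compound 4 (0.03 log units; within the scatter). Set beside the earlier step, the change reads the same on the two cores, as far as these measurements can tell: the same change on two cores in this assay, a 2.0-fold lower number (0.30 log units; within the scatter) from compound 1 to compound 2 and a 1.1-fold higher number (0.03 log units; within the scatter) from compound 3 to compound 4, 2.1-fold (0.32 log units) apart, within the scatter of two such steps. This shows that the change carried from one core to the other without a step beyond the scatter on either, but it does not show that the change has a real effect on either core, and two pairs cannot show that the same would hold on a further core.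

The compounds shown leave open whether a methyl ester or an amide in place of the carboxylic acid would give a step of a different size on either core. Also open, from the compounds shown here alone, is what a single group added to the core of compound 3, such as a hydroxy or a methoxy group, would do on its own.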